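From compound 3 to compound 4 on the benzyl chain

The source may report more compounds than this note shows. Statements on the series, on what has been measured and on what is new or still open speak of the compounds shown alone.

In a functional assay on HT-29 cells (Homo sapiens) for inhibition, read by MTT assay, with a stated time of 48 h (a lower number here means a stronger inhibitor, a higher number a weaker inhibitor), compound 1 `O=C1N/C(=N\Cc2ccccc2)S/C1=C1/CCNC(=O)c2[nH]ccc21` gives 36500 nM. Compound 2 `O=C1N/C(=N\Cc2ccc(Cl)cc2)S/C1=C1/CCNC(=O)c2[nH]ccc21` gives > 100000 nM, which is a limit and not a number. Compound 3 `O=C1N/C(=N\Cc2ccccc2Cl)S/C1=C1/CCNC(=O)c2[nH]ccc21` gives > 100000 nM, also only a limit. Compound 3 thus shares (the limit of > 100000 nM in this assay, at which 2 of the 3 values shown sit).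

Compound 4 `O=C1N/C(=N\Cc2ccc(F)cc2)S/C1=C1/CCNC(=O)c2[nH]ccc21` carries 4-fluorophenyl in place of 2-chlorophenyl on a saturated chain carbon bound to a double-bonded nitrogen.

For the measured compounds named here, two measured steps bear on this change, an at least 2.7-fold higher number from compound 1 to compound 2 (0.43 log units; beyond the scatter) and an at least 2.7-fold higher number from compound 1 to compound 3 (0.43 log units; beyond the scatter). Both are open-ended and beyond the scatter, and both add chloro. Going by the values given here, no measured step adds fluoro, so the size remains uncertain. The estimated change is an at least 1.4-fold lower number from compound 3 to compound 4 (0.15 log units; that floor lies within the scatter), toward a lower number. For compound 4 the expected value is 70000 nM, with an estimated range of 30000 nM to 160000 nM.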

Compound 4, half-maximal inhibitory concentration: 26000 nM
For compound 4 the middle estimate is 2.7-fold (0.43 log units) above the measured one, outside the stated range (below it).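

In this assay, the change from chloro to fluoro on the phenyl gives an at least 3.8-fold lower number from compound 2 to compound 4 (0.58 log units; beyond the scatter), and 4-fluorophenyl in place of 2-chlorophenyl gives an at least 3.8-fold lower number from compound 3 to compound 4 (0.58 log units; beyond the scatter). Fluoro in place of hydrogen gives a 1.4-fold lower number from compound 1 to compound 4 (0.15 log units; within the scatter), so the rise seen with chloro does not carry over to fluoro. Compound 2 and compound 3 remain limits, not numbers: the limit of > 100000 nM in this assay, at which 2 of the 4 values shown sit.

Going by these compounds, whether 2-fluorophenyl would behave like 4-fluorophenyl remains open. Also open, on these data alone, is whether an amine on the phenyl, or a longer chain in place of benzyl, would give a number clearly lower than that of compound 1.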